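Replacing a Carboxy Group with Methylcarbamoyl

The source may report more compounds than this note shows. Statements on the series, on what has been measured and on what is new or still open speak of the compounds shown alone.

Two compounds sharing one core have been examined in a functional assay on A2780 cells (Homo sapiens) for inhibition; a lower number here means a stronger inhibitor, a higher number a weaker inhibitor. Compound 1 `CCNC(=O)c1noc(-c2cc(C(C)C)c(O)cc2O)c1-c1cc(COCC(=O)O)no1` yielded no number, and its entry reads "not determined" (no result reported). Compound 2 `CCNC(=O)c1noc(-c2cc(C(C)C)c(O)cc2O)c1-c1cc(C(=O)O)no1` gives 20000 nM in this assay. Within the data shown here, that is the only measured value, so compound 2 cannot be ranked against any neighbour.

The next compound, compound 3 `CCNC(=O)c1noc(-c2cc(C(C)C)c(O)cc2O)c1-c1cc(C(=O)NC)no1`, differs from compound 2 at a single place: methylamino in place of hydroxy on a carbonyl carbon. It carries methylamino in place of hydroxy on a carbonyl carbon, so that carboxy becomes methylcarbamoyl and the rest of the structure stays the same.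

Among the measured compounds shown here, no measured pair shows what such a change does, and the expectation is therefore a judgement with a wide margin. A clear move towards stronger inhibition, well beyond the usual scatter, is expected in this assay. The expected size of the change is a 33-fold lower number from compound 2 to compound 3 (1.52 log units; beyond the scatter). For compound 3 the estimated value is 600 nM, with an expected range from 80 nM to 5000 nM.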

Compound 3, half-maximal inhibitory concentration: 100 nM
Beside the measured number, compound 3's estimate is 6.0-fold (0.78 log units) above it, and the stated range covers the measured number.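

Among these compounds, replacing carboxy with methylcarbamoyl on the carbonyl carbon gives a 200-fold lower number from compound 2 to compound 3 (2.30 log units; beyond the scatter) in this assay, the first measured evidence that the read-out responds to a change at this position. Only hydroxy gives way to methylamino, with the rest of the structure unchanged, so this single exchange accounts for the whole step between these two compounds. The compounds shown offer no information on why the amide outperforms the acid in this pair.

As far as these compounds go, the step rests on one pair in one core, and any step involving compound 1 cannot be read, so the effect of its longer chain ending in a carboxylic acid remains unknown. From the compounds shown here alone, it also remains open whether the gain is specific to methylamino or would persist with a plain amino group, ethylamino or dimethylamino on the same carbonyl carbon, and whether a methyl ester in that place would behave more like compound 2 or compound 3.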